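Propyl to Phenyl on the Shared Core: Tolerability Outlook

The compounds below may be only part of what the source reports. "The series", "measured", "known", "first", "only" and "open" are said of these compounds alone.

Compound 1 `CN1OC(n2cc3ccoc3nc2=O)CC1CO` was examined in an ADME assay on BSC-1 cells (Chlorocebus aethiops) for cytotoxicity, read by microscopy, with a stated time of 96 h; a lower number here means that less compound is tolerated, a higher number that more compound is tolerated. In this assay compound 1 gives only a limit, > 250000 nM. Compound 2 `CCCc1cc2cn(C3CC(CO)N(C)O3)c(=O)nc2o1` carries a propyl group on an aromatic carbon of the shared core. In this assay compound 2 likewise gives only a limit, > 250000 nM. The step that the two limits leave unreadable from compound 1 to compound 2 therefore cannot be read. Both values sit at the limit of > 250000 nM in this assay, at which 2 of the 2 values shown sit, so compound 2 stands at the upper edge of what this assay reports. Compound 3 `CN1OC(n2cc3cc(-c4ccccc4)oc3nc2=O)CC1CO` differs from compound 2 by phenyl in place of propyl on an aromatic carbon. Among the compounds with values here, no measured step covers exchanging propyl for phenyl, and the single step available is itself unreadable, so nothing here points to a size or a direction. Compound 3 is therefore expected to remain near the limit, with the estimated step of a number no higher from compound 2 to compound 3 (the limit leaves the size open) taken as within the scatter. The estimate for compound 3 in this assay is 250000 nM, between 120000 nM and 500000 nM.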

Compound 3, minimum cytotoxic concentration: > 250000 nM
Compound 3: no number, only a limit; the forecaster's own chance of this, stated with the estimate: 75%; the middle value lies on the limit itself.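

Within the data shown here, compound 1, compound 2 and compound 3 each give only a limit, so no step among them can be read in this assay: the limit of > 250000 nM in this assay, at which 3 of the 3 values shown sit. The compounds shown leave open whether hydrogen, propyl or phenyl on that aromatic carbon of the shared core makes any difference to how much compound is tolerated.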